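Replacing the 4-Ethylphenyl Group with Isobutyl on the Carbonyl

This account rests on a few compounds, and the source may have more. Where it says the series, first, only, none or still open, it means among the compounds named here.

Measured compounds:
compound 1 `Cc1cccc(Cn2c(CN3CCN(C(=O)c4ccc([N+](=O)[O-])cc4)CC3)nc3ccccc32)c1`: 24.3%
compound 2 `Cc1cccc(Cn2c(CN3CCN(C(=O)c4ccc(C(F)(F)F)cc4)CC3)nc3ccccc32)c1`: 22.9%
compound 3 `CCc1ccc(C(=O)N2CCN(Cc3nc4ccccc4n3Cc3cccc(C)c3)CC2)cc1`: 67%

In an assay on isolated protein for inhibition of aldehyde dehydrogenase 1A1 (Homo sapiens), read by spectrophotometry, tested at 10 uM (on this read-out higher numbers stand for more inhibition at the one concentration tested (going by the name of the read-out) and lower numbers for less inhibition), compound 3 gives 67%, the highest of the three numbers. The steps of a number 42.7 percentage points higher from compound 1 to compound 3 (beyond the scatter) and a number 44.1 percentage points higher from compound 2 to compound 3 (beyond the scatter) both lie beyond the scatter, while a number 1.4 percentage points lower from compound 1 to compound 2 (within the scatter) lies within it. Compound 4 `Cc1cccc(Cn2c(CN3CCN(C(=O)CC(C)C)CC3)nc3ccccc32)c1` carries a different kind of change: isobutyl in place of 4-ethylphenyl on a carbonyl carbon. Every measured step swapped one group on the six-membered aromatic ring of carbon only and kept that ring; here the ring itself leaves and a branched chain of four carbons enters. The measured steps therefore bear only loosely on this one. They show that the read-out shifts strongly with what sits on the 4-ethylphenyl group, but nothing shows what happens when that group is gone. Since the high number of compound 3 rests on the 4-ethylphenyl group, which compound 4 lacks, I expect compound 4 to lose inhibition, with an estimated step of a number 32 percentage points lower from compound 3 to compound 4 (beyond the scatter). My estimate for compound 4 is 35%, within a range of 10% to 62%.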

Compound 4, a percentage reported as inhibition, at one concentration (the size of the read-out at that concentration, not a potency): 71.4%
Estimate against measurement, compound 4: 36.4 percentage points below, outside the stated range (above it).
By their numbers in this assay, from the lowest: compounds 2 and 1 (each within the scatter of the next); then compounds 3 and 4 (each within the scatter of the next).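

In this assay, the aromatic ring on the carbonyl turns out not to be required: the change to isobutyl gives a number 4.4 percentage points higher from compound 3 to compound 4 (within the scatter) and so leaves the two compounds indistinguishable, even though the chain has no ring and fewer heavy atoms. The same chain also gives a number 48.5 percentage points higher from compound 2 to compound 4 (beyond the scatter) and a number 47.1 percentage points higher from compound 1 to compound 4 (beyond the scatter) against the other two compounds, so the low numbers at this place go with 4-(trifluoromethyl)phenyl and 4-nitrophenyl, not with every aromatic group. No measurement shown gives a reason for any of these steps.

Going by these compounds, it remains open whether a longer chain such as hexyl or a saturated ring such as cyclohexyl would keep this level of inhibition. On these data alone, it is equally open how the number would respond to an amine or a carboxylic acid at the end of the chain.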